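This account rests on a few compounds, and the source may have more. Where it says the series, first, only, none or still open, it means among the compounds named here.

Among the compounds with values here, both compounds measured so far sit at the edge of what a functional assay on HT-29 cells (Homo sapiens) for inhibition, read by MTT assay, with a stated time of 72 h (on this read-out lower numbers stand for stronger inhibition and higher numbers for weaker inhibition), can report. Compound 1 `COc1cc(/C=C/C(=O)/C=C(/C=C/c2ccc(OC(C)=O)c(OC)c2)NC2CCCCC2)ccc1OC(C)=O` gives > 25000 nM, which is a limit and not a number. Compound 2 `COc1cc(/C=C/C(=O)/C=C(/C=C/c2ccc(OC(C)=O)c(OC)c2)NCC(C)C)ccc1OC(C)=O` gives > 25000 nM, which is also a limit. The record for the series is therefore (the limit of > 25000 nM in this assay, at which 2 of the 2 values shown sit). Within the data shown here, the one measured step bearing on the next change is a step that the two limits leave unreadable from compound 1 to compound 2, so it offers no size to carry forward. Compound 3 `CCC(C)NC(=C\C(=O)/C=C/c1ccc(OC(C)=O)c(OC)c1)/C=C/c1ccc(OC(C)=O)c(OC)c1` has the same atoms as compound 2, joined differently, with sec-butyl in place of isobutyl on an amine nitrogen. A much larger change, a step that the two limits leave unreadable from compound 1 to compound 2, still left the read-out at the limit, so no change beyond the scatter is expected here, in either direction. The expected step is a step that the limit leaves unreadable from compound 2 to compound 3. For compound 3 the estimated value is 30000 nM, with an expected range of 15000 nM to 60000 nM.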

Compound 3, half-maximal inhibitory concentration: > 25000 nM
Compound 3 ended at the assay's limit; the forecaster's own chance of this, stated with the estimate: 85%; the middle value lies beyond the limit too.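

In this assay compound 3 gives > 25000 nM, which is a limit and not a number. No step among compound 1, compound 2 and compound 3 can be read, because all three share one limit: the limit of > 25000 nM in this assay, at which 3 of the 3 values shown sit.

How strongly each of these compounds inhibits, and whether the group on the amine nitrogen affects that, stays open.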